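The compounds below may be only part of what the source reports. "The series", "measured", "known", "first", "only" and "open" are said of these compounds alone.

Measured in a functional assay on A549 cells (Homo sapiens) for antiproliferative activity, read by sulforhodamine B assay, with a stated time of 48 h; a lower number here means a stronger inhibitor, a higher number a weaker inhibitor:
compound 1 `COc1cc(OC)c2sc(-c3ccc(N/C=C\C(=O)c4ccc(OC)c(O)c4)c(C)c3)nc2c1`: 14300 nM
compound 2 `COc1ccc(C(=O)/C=C\Nc2ccc(-c3nc4cc(OC)c(OC)c(OC)c4s3)cc2C)cc1O`: 15400 nM
compound 3 `COc1cc(OC)c2sc(-c3ccc(N/C=C\C(=O)c4ccc(OC)c(O)c4)cc3)nc2c1`: 10600 nM

Compound 2 carries the highest of the three numbers, but compound 1 and compound 3 both sit within the scatter of it, so the three measured compounds are not separable in this assay. Compound 4 `COc1ccc(C(=O)/C=C\Nc2ccc(-c3nc4cc(OC)c(OC)c(OC)c4s3)cc2C)cc1F` differs from compound 2 by fluoro in place of hydroxy on an aromatic carbon. Neither measured step alters this part of the molecule: a 1.1-fold higher number from compound 1 to compound 2 (0.03 log units; within the scatter) and a 1.3-fold lower number from compound 1 to compound 3 (0.13 log units; within the scatter) concern other positions, and both lie within the scatter. The series therefore gives no direct reading of the hydroxy-to-fluoro change. A step of a 1.0-fold lower number from compound 2 to compound 4 (0.01 log units; within the scatter) is expected, with nothing beyond the scatter clearly indicated. Compound 4 is estimated at 15000 nM, range 6000 nM to 40000 nM.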

Compound 4, half-maximal inhibitory concentration: 1690 nM
For compound 4 the middle estimate is 8.9-fold (0.95 log units) above the measured one; measured number outside the range, below it.
By their numbers in this assay, from the lowest: compound 4; then compounds 3, 1 and 2 (each within the scatter of the next).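

In this assay, going by these compounds alone, the change from 3-hydroxy-4-methoxyphenyl to 3-fluoro-4-methoxyphenyl gives a 9.1-fold lower number from compound 2 to compound 4 (0.96 log units; beyond the scatter) and is the first step to pass the scatter, so this position affects the number where the earlier changes did not. The change removes one hydrogen-bond donor and one hydrogen-bond acceptor, but no measurement available here accounts for the step.

On these data alone, whether the gain follows fluoro itself or the loss of hydroxy stays open; hydrogen, chloro or an amine at this position would separate the two. As far as these compounds go, whether it carries over to the cores of compound 1 and compound 3 also stays open.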